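This account rests on a few compounds, and the source may have more. Where it says the series, first, only, none or still open, it means among the compounds named here.

Of the compounds shown here, two of a shared core have been measured in a functional assay on cells for agonist activity at Glucose-dependent insulinotropic receptor (Homo sapiens), read by HTRF and cAMP accumulation, with a stated time of 30 min; a lower number here means that less compound is needed, a higher number that more compound is needed for the effect. Compound 1 `CC(C)(C)OC(=O)N1CCC2(CC1)CC2CCCOc1ccc(S(C)(=O)=O)cc1` gives 830 nM in this assay. Compound 2 `CC(C)(C)OC(=O)N1CCC2(CC1)CC(CCCOc1ccc(S(C)(=O)=O)c(F)c1)C2` carries a fluorine on the aromatic ring and a different attachment on the spirocyclic core; in this assay compound 2 gives 9 nM, the lower of the two numbers, and the gap to compound 1 lies beyond the usual scatter.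

Compound 3 `CC(C)OC(=O)N1CCC2(CC1)CC(CCCOc1ccc(S(C)(=O)=O)c(F)c1)C2` differs from compound 2 in one place: hydrogen in place of methyl on a saturated chain carbon bound to an oxygen next to a carbonyl group and two saturated chain carbons, that is, tert-butoxycarbonyl becomes isopropoxycarbonyl on the carbamate nitrogen. Among the compounds with values here, no measured pair shows this change, so its effect is unknown. Since both measured compounds keep the tert-butoxycarbonyl group, the expectation for compound 3 rests on the value of compound 2 alone; a small rise in the number is expected, a 2.2-fold higher number from compound 2 to compound 3 (0.35 log units; beyond the scatter), close to the scatter. Compound 3 is therefore estimated at 20 nM, with a range from 6 nM to 70 nM.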

Compound 3, half-maximal effective concentration: 18 nM
Compound 3: the middle estimate sits 1.1-fold (0.05 log units) above what was measured; the measured number falls inside the stated range.
By their numbers in this assay, from the lowest: compounds 2 and 3 (each within the scatter of the next); then compound 1.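

In this assay the change from tert-butoxycarbonyl to isopropoxycarbonyl gives a 2.0-fold higher number from compound 2 to compound 3 (0.30 log units; within the scatter) and is the first direct test of this position among the compounds shown. Compound 2 and compound 3 cannot be told apart here, so the full tert-butyl group is not required to keep the number in this range, and one methyl can leave without a change that stands out from repeat measurements. Nothing available explains this result.

As far as these compounds go, whether smaller groups such as ethoxycarbonyl or methoxycarbonyl, or a different group such as an amide, would keep the number in this range remains open. Also open, from the compounds shown here alone, is whether the same change from tert-butyl to isopropyl would behave alike on the core of compound 1.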